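This account rests on a few compounds, and the source may have more. Where it says the series, first, only, none or still open, it means among the compounds named here.

Of the compounds shown here, two have been measured so far in a functional assay on MC-38 cells (Mus musculus) for antiproliferative activity; a lower number here means a stronger inhibitor, a higher number a weaker inhibitor. Compound 1, `N#Cc1ccc(S(=O)(=O)Nc2cccc3cc[nH]c23)cc1`, gives 1.8 ug/mL, while compound 2, `COc1ccc(S(=O)(=O)Nc2cccc3c(C#N)c[nH]c23)cc1`, gives 0.17 ug/mL. Compound 2 therefore holds the lower of the two numbers, and the gap between them lies beyond the usual scatter of repeated measurements. These two compounds differ in more than one place, so their gap cannot be assigned to any single change.

The next compound, compound 3, `N#Cc1ccc(S(=O)(=O)Nc2cccc3c(C#N)c[nH]c23)cc1`, is compound 2 with one substitution: cyano in place of methoxy on an aromatic carbon, para to a large group. cyano in place of methoxy on an aromatic carbon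

Within the data shown here, no pair of measured compounds shows this swap on its own, so there is no direct precedent for its size or direction. The starting point is therefore compound 2 at 0.17 ug/mL, with a small rise in the number as a cautious guess. The expected change is a 1.5-fold higher number from compound 2 to compound 3 (0.17 log units; within the scatter), which would not go beyond the scatter. The estimated value for compound 3 is 0.25 ug/mL, with an expected range from 0.06 ug/mL to 1 ug/mL.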

Compound 3, half-maximal inhibitory concentration: 0.12 ug/mL
Estimate against measurement, compound 3: 2.1-fold (0.32 log units) above, and the stated range covers the measured number.
By their numbers in this assay, from the lowest: compounds 3 and 2 (each within the scatter of the next); then compound 1.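

Replacing methoxy with cyano on an aromatic carbon, para to a large group, gives a 1.4-fold lower number from compound 2 to compound 3 (0.15 log units; within the scatter) in this assay, so at this position the two groups cannot be told apart in this assay, at least on this core. The other change gives the first clear single-place effect in the series: cyano in place of hydrogen on an aromatic carbon of the shared core gives a 15-fold lower number from compound 1 to compound 3 (1.18 log units; beyond the scatter) while the cyano para to a large group stays the same, so the large gap belongs to this one change. No measurement on hand gives a reason for either step.

From the compounds shown here alone, at the position para to a large group, only methoxy and cyano appear, so it remains open whether an amine or a carboxylic acid there would also leave the number within the scatter of these two. Going by these compounds, on the core carbon, only hydrogen and cyano can be compared, so it also remains open whether a methyl group or a carboxamide there would bring a step as large as the one seen with cyano.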